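This account rests on a few compounds, and the source may have more. Where it says the series, first, only, none or still open, it means among the compounds named here.

Measured compounds in a functional assay on A549 cells (Homo sapiens) for antiproliferative activity, read by MTT assay, with a stated time of 48 h; a lower number here means a stronger inhibitor, a higher number a weaker inhibitor:

compound 1, `COc1cc(/C=N/c2c(C#N)ncn2-c2ccc(F)cc2)cc(OC)c1OC`, gives 9880 nM;
compound 2, `COc1ccc(OC)c(/C=N/c2c(C#N)ncn2-c2ccc(F)cc2)c1`, gives 9280 nM;
compound 3, `COc1cc(/C=N/c2c(C#N)ncn2Cc2ccc(F)cc2)cc(OC)c1OC`, gives 9710 nM.

All three values in this assay sit within the scatter of one another, so no order among them is claimed. The difference between the core of compound 1 and the core of compound 2 is not broken down here. Among the measured compounds shown here, the one counted change, (4-fluorobenzyl in place of 4-fluorophenyl on an aromatic nitrogen), gave a 1.0-fold lower number from compound 1 to compound 3 (0.01 log units; within the scatter).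

Compound 4, `COc1ccc(OC)c(/C=N/c2c(C#N)ncn2Cc2ccc(F)cc2)c1`, is not yet measured in this assay. It carries the same change against compound 2, (4-fluorobenzyl in place of 4-fluorophenyl on an aromatic nitrogen), at the same place. The step from compound 2 to compound 4 is expected to be about a 1.0-fold higher number from compound 2 to compound 4 (0.00 log units; within the scatter), because a 1.0-fold lower number from compound 1 to compound 3 (0.01 log units; within the scatter) showed no movement beyond the scatter. The estimate for compound 4 in this assay is 9300 nM, expected between 5000 nM and 17000 nM.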

Compound 4, half-maximal inhibitory concentration: 13100 nM
Compound 4: the middle estimate sits 1.4-fold (0.15 log units) below what was measured, and the stated range covers the measured number.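

In this assay, 4-fluorobenzyl in place of 4-fluorophenyl on the aromatic nitrogen gives a 1.4-fold higher number from compound 2 to compound 4 (0.15 log units; within the scatter). Set beside the earlier step, the change reads the same on both cores: the same change on two cores in this assay, a 1.0-fold lower number (0.01 log units; within the scatter) from compound 1 to compound 3 and a 1.4-fold higher number (0.15 log units; within the scatter) from compound 2 to compound 4, 1.4-fold (0.16 log units) apart, within the scatter of two such steps. This shows that the swap leaves the number within the scatter on these two cores, but it does not show that the two groups are interchangeable on other cores or that the same would hold in another test.

From the compounds shown here alone, whether any change at this nitrogen can move the number beyond the scatter remains open, for example a longer chain or a chain ending in an amine. Also open, going by these compounds, is whether a carboxylic acid in place of the nitrile would do so.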